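Replacing 4-hydroxy-2-methylphenyl with 4-ethylphenyl in a growth inhibitor

The compounds below may be only part of what the source reports. "The series", "measured", "known", "first", "only" and "open" are said of these compounds alone.

Compound 1 `Cc1ccc(C2=NN(c3ccc(S(C)(=O)=O)cc3)C(=O)CC2)cc1` gives 1150 nM
Compound 2 `Cc1cc(O)ccc1C1=NN(c2ccc(S(C)(=O)=O)cc2)C(=O)CC1` gives 9770 nM

In a functional assay on SK-OV-3 cells (Homo sapiens) for inhibition, read by sulforhodamine B assay, with a stated time of 48 h (a lower number here means a stronger inhibitor of growth, a higher number a weaker inhibitor of growth), compound 2 gives 9770 nM and this is the higher of the two numbers, which makes it the weaker inhibitor of growth of the pair. Compound 3 `CCc1ccc(C2=NN(c3ccc(S(C)(=O)=O)cc3)C(=O)CC2)cc1` has not yet been measured. It has 4-ethylphenyl in place of 4-hydroxy-2-methylphenyl on a carbon with a double bond to nitrogen, and the counted difference from compound 2 is 4-ethylphenyl in place of 4-hydroxy-2-methylphenyl on a carbon with a double bond to nitrogen in full. Among the measured compounds shown here, one measured step bears on this change. It is an 8.5-fold higher number from compound 1 to compound 2 (0.93 log units; beyond the scatter) and it brought in the same 4-hydroxy-2-methylphenyl group that compound 3 lacks. For the measured compounds named here, no measured compound carries 4-ethylphenyl, so a single step is thin evidence. Even so, a step of similar size toward a lower number is expected in this assay for this change. The estimated step is a 6.5-fold lower number from compound 2 to compound 3 (0.81 log units; beyond the scatter). The estimated value for compound 3 is 1500 nM with an expected range from 500 nM to 4500 nM in this estimate.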

Compound 3, concentration for 50% growth inhibition: 2440 nM
For compound 3 the middle estimate is 1.6-fold (0.21 log units) below the measured one; the range from low to high includes it.
By their numbers in this assay, from the lowest: compound 1; then compound 3; then compound 2.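

In this assay, among the compounds shown here, the step of a 4.0-fold lower number from compound 2 to compound 3 (0.60 log units; beyond the scatter) shows that 4-hydroxy-2-methylphenyl is not the only group whose replacement moves the number at this position: 4-ethylphenyl, which has 0 hydrogen-bond donors and 0 hydrogen-bond acceptors, also gives a stronger inhibitor of growth than compound 2. The position also responds to a much smaller change, since the step of a 2.1-fold higher number from compound 1 to compound 3 (0.33 log units; beyond the scatter) comes from turning the methyl of 4-methylphenyl into the ethyl of 4-ethylphenyl, so compound 3 recovers much of the ground lost in compound 2 without matching compound 1. Nothing given here explains why either change shifts growth inhibition.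

Compound 2 and compound 3 differ in the whole group, so the compounds shown cannot separate the part played by the hydroxyl from that of the ring methyl, a question that 4-hydroxyphenyl could address. They also leave open whether the trend from methyl to ethyl continues with a longer chain such as propyl, and how an amine or a carboxylic acid on this phenyl ring would behave.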